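The compounds below may be only part of what the source reports. "The series", "measured", "known", "first", "only" and "open" are said of these compounds alone.

Measured so far:
Compound 1 `COc1ccc(/C=C/C(=O)c2sc(Nc3ccc(Cl)cc3)nc2C)cc1` gives > 25000 nM in a functional assay on BGC-823 cells (Homo sapiens) for cytotoxicity, read by MTT assay; a lower number here means a stronger inhibitor, a higher number a weaker inhibitor.
Compound 2 `COc1cc(/C=C/C(=O)c2sc(Nc3ccc(Cl)cc3)nc2C)cc(OC)c1OC` gives > 25000 nM in this assay.

For compound 1 this figure is not a number but a limit of this assay. For compound 2 the figure is likewise a limit and not a number. Both measured values sit at the limit of > 25000 nM in this assay, at which 2 of the 2 values shown sit, so compound 1 stands at the limit together with compound 2, and no order between the two can be drawn; each is simply a weak inhibitor on the numbers shown, with no numbered value anywhere in the set.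

Compound 3 `Cc1nc(Nc2ccc(Cl)cc2)sc1C(=O)/C=C/c1ccc(Cl)cc1` has not yet been measured. It differs from compound 1 by chloro in place of methoxy on an aromatic carbon. For the measured compounds named here, no step between two measured compounds with numbered values is available, so nothing in the data shows how this exchange moves activity in this assay. With both measured compounds resting at the limit, the plain expectation is that compound 3 also returns only a limit, or a number near it. The expected step that the limit leaves unreadable from compound 1 to compound 3 is therefore none beyond the scatter. The estimate for compound 3 is 30000 nM, with a range from 8000 nM to 100000 nM.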

Compound 3, half-maximal inhibitory concentration: > 25000 nM
Compound 3: no number, only a limit (the forecaster's own chance of this, stated with the estimate: 70%); the middle value lies beyond the limit too.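

Compound 3, like compound 1, gives only a limit and not a number in this assay, so the step from methoxy to chloro between compound 1 and compound 3 cannot be read. All the values shown rest at the same limit: the limit of > 25000 nM in this assay, at which 3 of the 3 values shown sit. The compounds shown leave open whether any change on the shared core yields a numbered value in this assay at all.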